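This account rests on a few compounds, and the source may have more. Where it says the series, first, only, none or still open, it means among the compounds named here.

Working notes on the series. In an assay (Cricetulus griseus) for inhibition of aldehyde dehydrogenase, mitochondrial (Homo sapiens) (a lower number here means a stronger inhibitor, a higher number a weaker inhibitor), compound 3 `O=C(O)CCCCCCCOc1ccc2c(=O)c(-c3ccc(O)cc3)coc2c1` gives 40 nM, the lowest of the two numbers shown. Compound 2 `O=C(O)CCCCOc1ccc2c(=O)c(-c3ccc(O)cc3)coc2c1` gives 100 nM in this assay. For compound 1 `O=C(O)CCCCCCCCCCCCCCCOc1ccc2c(=O)c(-c3ccc(O)cc3)coc2c1` this assay reports only a limit, > 9000 nM. Two single-point steps connect the measured compounds: an at least 220-fold lower number from compound 1 to compound 3 (2.35 log units; beyond the scatter), which rests on the limit (the limit of > 9000 nM in this assay, at which 1 of the 3 values shown sits), and a 2.5-fold lower number from compound 2 to compound 3 (0.40 log units; beyond the scatter). Both steps change only the length of the chain that ends in the carboxy group, and the shorter chains give the lower numbers.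

Compound 4 `O=c1c(-c2ccc(O)cc2)coc2cc(OCCCCCCO)ccc12` is not yet measured. It differs from compound 3 in one place: hydroxy in place of carboxymethyl on a saturated chain carbon, six bonds along the chain from an oxygen on an aromatic ring. Among the compounds with values here, no recorded step covers the loss of the carboxy end itself, so the two steps give only an indirect reading: the chain becomes shorter, which in the recorded steps went with lower numbers, but the acid end, present in every measured compound, is gone. Compound 4 is therefore expected to give about 150 nM in this assay, with an expected range from 40 nM to 600 nM. That estimate amounts to an expected step of a 3.8-fold higher number from compound 3 to compound 4 (0.57 log units; beyond the scatter).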

Compound 4, half-maximal inhibitory concentration: 120 nM
The estimate for compound 4 lay 1.3-fold (0.10 log units) above the measured number; low and high end bracket the measured number.
By their numbers in this assay, from the lowest: compound 3; then compounds 2 and 4 (each within the scatter of the next). At a limit, above all of these: compound 1.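

In this assay, a carboxy end proves not to be required for a number of this order: compound 4, the only compound shown without one, carries a hydroxy end, and a 1.2-fold higher number from compound 2 to compound 4 (0.08 log units; within the scatter). The acid of compound 3 still gives the lowest number, with a 3.0-fold higher number from compound 3 to compound 4 (0.48 log units; beyond the scatter). A large gap remains to the longest chain, an at least 75-fold lower number from compound 1 to compound 4 (1.87 log units; beyond the scatter), and that step rests on a limit: the limit of > 9000 nM in this assay, at which 1 of the 4 values shown sits.

The step to the hydroxy end also shortens the chain, so the compounds shown do not separate the effect of the end group from that of chain length. On these data alone, whether a hydroxy end on a longer chain, or an amine or a methyl ester at the chain end, would read like compound 4 stays open.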